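A Hydroxy Gain and a Dimethoxyphenyl Swap on One Core

This account rests on a few compounds, and the source may have more. Where it says the series, first, only, none or still open, it means among the compounds named here.

The measured compounds, each with its result in a functional assay on A2780 cells (Homo sapiens) for inhibition, read by sulforhodamine B assay; on this read-out lower numbers stand for stronger inhibition of growth and higher numbers for weaker inhibition of growth:
compound 1, `Clc1cccc(-c2ccc(-c3ccc(-c4nc5ccccc5[nH]4)cc3)cc2)c1`, gives 31100 nM;
compound 2, `COc1ccc(-c2ccc(-c3ccc(-c4nc5ccccc5[nH]4)cc3)cc2)cc1OC`, gives 21600 nM;
compound 3, `Oc1cccc2[nH]c(-c3ccc(-c4ccc(-c5cccc(Cl)c5)cc4)cc3)nc12`, gives 2800 nM.

Two changes separate these three compounds. From compound 1 to compound 2 the change is 3,4-dimethoxyphenyl in place of 3-chlorophenyl on an aromatic carbon, and in this assay it produced a 1.4-fold lower number from compound 1 to compound 2 (0.16 log units; within the scatter). From compound 1 to compound 3 the change is hydroxy in place of hydrogen on an aromatic carbon, and it produced an 11-fold lower number from compound 1 to compound 3 (1.05 log units; beyond the scatter), leaving compound 3 with the lowest number of the three.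

Compound 4, `COc1ccc(-c2ccc(-c3ccc(-c4nc5c(O)cccc5[nH]4)cc3)cc2)cc1OC`, is not yet measured. It differs from compound 3 by 3,4-dimethoxyphenyl in place of 3-chlorophenyl on an aromatic carbon, the same change already seen between compound 1 and compound 2, made here on the core that carries the hydroxy of compound 3. The place of the change is described in the same words for both pairs.

Because the earlier instance gave a 1.4-fold lower number from compound 1 to compound 2 (0.16 log units; within the scatter), the step from compound 3 to compound 4 is expected to be similar, about a 1.3-fold lower number from compound 3 to compound 4 (0.12 log units; within the scatter) in this assay. Within the data shown here, compound 4 is therefore estimated at 2100 nM, with a likely range from 800 nM to 5500 nM, since only one earlier example of this change supports the expectation.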

Compound 4, concentration for 50% growth inhibition: 2710 nM
Compound 4: middle estimate off by 1.3-fold (0.11 log units), on the low side; measured number inside the range.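

In this assay, 3,4-dimethoxyphenyl in place of 3-chlorophenyl on the core carrying the hydroxy gave a 1.0-fold lower number from compound 3 to compound 4 (0.01 log units; within the scatter), which agrees with the step for the same change on the core without the hydroxy: the same change on two cores in this assay, a 1.4-fold lower number (0.16 log units; within the scatter) from compound 1 to compound 2 and a 1.0-fold lower number (0.01 log units; within the scatter) from compound 3 to compound 4, 1.4-fold (0.14 log units) apart, within the scatter of two such steps. Hydroxy in place of hydrogen gave an 8.0-fold lower number from compound 2 to compound 4 (0.90 log units; beyond the scatter) with 3,4-dimethoxyphenyl present, which agrees with the step seen with 3-chlorophenyl present: the same change on two cores in this assay, an 11-fold lower number (1.05 log units; beyond the scatter) from compound 1 to compound 3 and an 8.0-fold lower number (0.90 log units; beyond the scatter) from compound 2 to compound 4, 1.4-fold (0.14 log units) apart, within the scatter of two such steps. Across these four compounds, each change therefore carried from one core to the other with its size kept within the scatter, but this rests on a single pair of steps for each change and does not show that it would hold on any other core or explain why the hydroxy step is large.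

As far as these compounds go, whether an amine or a carboxylic acid in place of the hydroxy would give a step of similar size remains open. So does whether a methoxy or a longer ether chain at that place would keep it.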